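Series notes: from compound 3 to compound 4

This account rests on a few compounds, and the source may have more. Where it says the series, first, only, none or still open, it means among the compounds named here.

Measured compounds:
- compound 1 `CCCc1ccc(C#CC#Cc2cn([C@H]3C[C@H](O)[C@@H](CO)O3)c(=O)[nH]c2=O)cc1`: 52000 nM
- compound 2 `COc1cc(C#CC#Cc2cn([C@H]3C[C@H](O)[C@@H](CO)O3)c(=O)[nH]c2=O)cc(OC)c1`: > 100000 nM (a limit)
- compound 3 `Nc1ccc(C#CC#Cc2cn([C@H]3C[C@H](O)[C@@H](CO)O3)c(=O)[nH]c2=O)cc1`: > 100000 nM (a limit)

In an ADME assay on HEL cells (Homo sapiens), read by cell counting, with a stated time of 3 days (on this read-out lower numbers stand for higher toxicity in this test and higher numbers for lower toxicity in this test), compound 3 gives > 100000 nM, which is a limit and not a number. The same holds for compound 2, so the series stands largely at the limit of > 100000 nM in this assay, at which 2 of the 3 values shown sit. Only compound 1 gives a number, 52000 nM.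

The next compound is compound 4 `O=c1[nH]c(=O)n([C@H]2C[C@H](O)[C@@H](CO)O2)cc1C#CC#CCO`. Its change is hydroxymethyl in place of 4-aminophenyl on a triple-bonded carbon. Among the compounds with values here, no measured step makes this exact change. The nearest steps alter the same end of the molecule: an at least 1.9-fold higher number from compound 1 to compound 2 (0.28 log units; that floor lies within the scatter), an at least 1.9-fold higher number from compound 1 to compound 3 (0.28 log units; that floor lies within the scatter) and a step that the two limits leave unreadable from compound 2 to compound 3. The first two are floors within the scatter, and the third cannot be read. These steps give no basis for a step beyond the scatter in this assay, in either direction, and none is expected.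

The expected step is a number no higher from compound 3 to compound 4 (the limit leaves the size open).

For compound 4 the estimate is 100000 nM, with an expected range of 30000 nM to 200000 nM.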

Compound 4, half-maximal cytotoxic concentration in the HEL assay: > 100000 nM
Compound 4: only a limit was reported (the forecaster's own chance of this, stated with the estimate: 75%); the middle value sits exactly at the limit.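

In the HEL assay the end group on this triple-bonded carbon can lose its aromatic ring altogether, as hydroxymethyl, and the series still sits at the limit: the limit of > 100000 nM in the HEL assay, at which 3 of the 4 values shown sit. Within the data shown here, the only readable step, an at least 1.9-fold higher number from compound 1 to compound 4 (0.28 log units; that floor lies within the scatter), is a floor, and the steps between the compounds at the limit cannot be read. Compound 3 and compound 4 both sit at that limit in the HEL assay, although the change separates them clearly in a physicochemical assay for lipophilicity; on this read-out lower numbers stand for lower lipophilicity and higher numbers for higher lipophilicity: the measured partition coefficient of compound 3, 0.13, and of compound 4, -1.45, a number 1.58 log units lower (beyond the scatter). In the physicochemical assay compound 3 gives 0.13 and compound 4 gives -1.45.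

Among these compounds, compound 1, with 4-propylphenyl, remains the only compound with a number in the HEL assay, 52000 nM, and a single number does not show what sets it. On these data alone, whether a longer alkyl chain in place of propyl, or a carboxylic acid in place of hydroxymethyl, would give a number rather than a limit stays open.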